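This account rests on a few compounds, and the source may have more. Where it says the series, first, only, none or still open, it means among the compounds named here.

Series notes. Compound 1 `O=C1NNC(=O)C2(CSC3=C2C(=O)c2ncccc2C3=O)N1` gives 980 nM in a functional assay on HeLa cells (Homo sapiens) for antiproliferative activity, read by MTT assay, with a stated time of 96 h; on this read-out lower numbers stand for stronger inhibition and higher numbers for weaker inhibition. Compound 2 `O=C1C2=C(C(=O)c3ncccc31)C1(CS2)NC(=O)N(c2ccc(Cl)cc2)C1=O` gives 2 nM in this assay, the lowest number of the three measured, and compound 3 `Cc1ccc(N2NC(=O)NC3(CSC4=C3C(=O)c3ncccc3C4=O)C2=O)cc1` gives 210 nM in this assay. Among the measured compounds shown here, the one single-point step measured, a 4.7-fold lower number from compound 1 to compound 3 (0.67 log units; beyond the scatter), concerns an amide-type nitrogen in a ring of the shared core and not the aromatic ring substituent. Compound 4 `CCCCCc1ccc(N2C(=O)NC3(CSC4=C3C(=O)c3ncccc3C4=O)C2=O)cc1` differs from compound 2 by pentyl in place of chloro on an aromatic carbon, the pentyl sitting para to a large group. For the measured compounds named here, no measured step bears directly on this change, and the gap from compound 2 to compound 3 spans two alterations at once, so it gives no clean reading. A modest move toward higher numbers in this assay is expected, a 5.0-fold higher number from compound 2 to compound 4 (0.70 log units; beyond the scatter), with the uncertainty skewed toward a larger loss. Compound 4 is therefore estimated at 10 nM in this assay, with a range of 2 nM to 60 nM.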

Compound 4, half-maximal inhibitory concentration: 200 nM
Compound 4: the middle estimate sits 20-fold (1.30 log units) below what was measured, and the stated range ends below it.
By their numbers in this assay, from the lowest: compound 2; then compounds 4 and 3 (each within the scatter of the next); then compound 1.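

Pentyl in place of chloro, on an aromatic carbon para to a large group, brings a 100-fold higher number from compound 2 to compound 4 (2.00 log units; beyond the scatter) in this assay. Among the compounds shown here, this is the first single-place reading at this carbon, and it shows that the number here depends strongly on the group carried there. No available data account for the size of this step.

Going by these compounds, whether the loss follows chain length or the absence of chloro stays open. An ethyl or butyl chain, or a bromo group, at this carbon would help separate the two.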